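Trifluoromethyl for cyano on an aromatic carbon

The compounds below may be only part of what the source reports. "The series", "measured", "known", "first", "only" and "open" are said of these compounds alone.

In a functional assay on A549 cells (Homo sapiens) for inhibition, read by CCK-8 assay, with a stated time of 72 h, tested at 1 uM (a higher number here means more inhibition of growth at the concentration tested, a lower number less inhibition of growth), compound 1 (`CN(C)C(=O)c1cc2cnc(Nc3ccc(NC(=O)C4(C(=O)Nc5ccccc5F)CC4)cc3)nc2n1C1CCCC1`) gives 79.1%. Compound 2 (`CN(C)C(=O)c1cc2cnc(Nc3ccc(NC(=O)C4(C(=O)Nc5cccc(C#N)c5)CC4)cc3)nc2n1C1CCCC1`) gives 70.8%, which lies within the scatter of the value for compound 1. Compound 3 (`CN(C)C(=O)c1cc2cnc(Nc3ccc(NC(=O)C4(C(=O)Nc5cccc(C(F)(F)F)c5)CC4)cc3)nc2n1C1CCCC1`) differs from compound 2 in one group: trifluoromethyl in place of cyano on an aromatic carbon, meta to a large group (trifluoromethyl in place of cyano on an aromatic carbon). For the measured compounds named here, only one measured step bears on this change: a number 8.3 percentage points lower from compound 1 to compound 2 (within the scatter), with 3-cyanophenyl in place of 2-fluorophenyl on an amide-type nitrogen. Going by the values given here, that exchange is a different one, and no measurement yet shows cyano giving way to trifluoromethyl. With that single step as the guide, no step beyond the scatter is expected in this assay. The estimate amounts to an expected a number 1.2 percentage points higher from compound 2 to compound 3 (within the scatter). For compound 3 the expected value is 72%, with an estimated range of 58% to 85%.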

Compound 3, percent growth inhibition at one concentration: 15.7%
Beside the measured number, compound 3's estimate is 56.3 percentage points above it; the measured number lies below the stated range.
By their numbers in this assay, from the lowest: compound 3; then compounds 2 and 1 (each within the scatter of the next).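

In this assay this aromatic carbon proves far less forgiving than the earlier pair suggested: trifluoromethyl in place of cyano gives a number 55.1 percentage points lower from compound 2 to compound 3 (beyond the scatter), a large loss from a single exchange of one small group for another. Set against the 2-fluorophenyl compound, the 3-(trifluoromethyl)phenyl group gives a number 63.4 percentage points lower from compound 1 to compound 3 (beyond the scatter), so compound 3 stands apart from both earlier compounds, which themselves lie within the scatter of each other. The data shown offer no explanation for this fall.

On these data alone, whether a methoxy group, a chlorine atom or an amine on the same aromatic carbon would keep the number of compound 2 or drop towards that of compound 3 remains open. Also open, as far as these compounds go, is whether the same exchange would have a comparable effect on other cell lines.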